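This account rests on a few compounds, and the source may have more. Where it says the series, first, only, none or still open, it means among the compounds named here.

Measured so far:
compound 1 `Cc1ccc(C(=O)Nc2cccc(-c3oc4cc(-c5ccc(F)cc5)ccc4c(=O)c3O)c2)cc1` — 6190 nM
compound 2 `Cc1ccccc1C(=O)Nc1cccc(-c2oc3cc(-c4ccc(F)cc4)ccc3c(=O)c2O)c1` — 11900 nM

In a functional assay on HeLa cells (Homo sapiens) for antiproliferative activity, read by CCK-8 assay, with a stated time of 72 h (a lower number here means a stronger inhibitor, a higher number a weaker inhibitor), compound 1 gives 6190 nM and compound 2 gives 11900 nM. Compound 2 stands with compound 1 inside the usual scatter, since the step of a 1.9-fold higher number from compound 1 to compound 2 (0.28 log units; within the scatter) is within it. Compound 3 `O=C(Nc1cccc(-c2oc3cc(-c4ccc(F)cc4)ccc3c(=O)c2O)c1)c1ccc(Br)cc1` differs from compound 2 by 4-bromophenyl in place of 2-methylphenyl on a carbonyl carbon. Going by the values given here, no measured step touches a bromine group; the only step on this carbonyl position, a 1.9-fold higher number from compound 1 to compound 2 (0.28 log units; within the scatter), was within the scatter. The number for compound 3 is therefore expected near those of the two measured compounds, with the step of a 1.8-fold lower number from compound 2 to compound 3 (0.26 log units; within the scatter) as a guess only. Compound 3 is estimated at 6500 nM, between 2500 nM and 17000 nM.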

Compound 3, half-maximal inhibitory concentration: 9740 nM
Compound 3: the middle estimate sits 1.5-fold (0.18 log units) below what was measured, within the range that was stated.
By their numbers in this assay, from the lowest: compounds 1, 3 and 2 (each within the scatter of the next).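

In this assay, a halogen now appears on this aromatic ring, and the number stays within the scatter both against the ortho-free comparison

Correction to the above, final text:

In this assay, 4-bromophenyl on this carbonyl carbon leaves the number within the scatter of 2-methylphenyl (a 1.2-fold lower number from compound 2 to compound 3 (0.09 log units; within the scatter)). Bromo in place of methyl on the aromatic carbon also stays within the scatter (a 1.6-fold higher number from compound 1 to compound 3 (0.20 log units; within the scatter)), so the first halogen at this position separates nothing among the three compounds. No available evidence bears on this flat result. Open, going by these compounds, is whether any group on this carbonyl carbon moves the number beyond the scatter. An amine, a carboxylic acid or a longer alkyl chain in place of the aromatic ring would test this.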